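The source may report more compounds than this note shows. Statements on the series, on what has been measured and on what is new or still open speak of the compounds shown alone.

Going by the values given here, compound 2 `Nc1scc(CN2CCN(c3ccccc3C(F)(F)F)CC2)c1C(=O)c1ccc(Cl)cc1` gives 0% in a functional assay on CHO cells with adenosine receptor A1 (Homo sapiens) as the target, read by cAMP accumulation and immunoassay, with a stated time of 6 min, tested at 0.01 uM (on this read-out lower numbers stand for a stronger effect and higher numbers for a weaker effect at the one concentration tested), the smaller of the two numbers so far, though the gap to compound 1 is within the scatter. Compound 1 `Nc1scc(CN2CCN(c3ccc(F)cc3Cl)CC2)c1C(=O)c1ccc(Cl)cc1` gives 6.1% in this assay, and the step of a number 6.1 percentage points lower from compound 1 to compound 2 (within the scatter) is the only one on record at this position. Compound 3 `Nc1scc(CN2CCN(c3ccc(Cl)c(C(F)(F)F)c3)CC2)c1C(=O)c1ccc(Cl)cc1` carries 4-chloro-3-(trifluoromethyl)phenyl in place of 2-(trifluoromethyl)phenyl on an amine nitrogen in a ring. Among the compounds with values here, since the one comparable aryl swap on that ring nitrogen moved nothing beyond the scatter, no step beyond the scatter is expected for a number 4 percentage points higher from compound 2 to compound 3 (within the scatter). For compound 3 the estimate in this assay is 4%, with a range of -8% to 16%.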

Compound 3, a percentage reported as activity, at one concentration (the size of the read-out at that concentration, not a potency): -2.5%
Estimate against measurement, compound 3: 6.5 percentage points above, and the stated range covers the measured number.
By their numbers in this assay, from the lowest: compounds 3, 2 and 1 (each within the scatter of the next).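

With 4-chloro-3-(trifluoromethyl)phenyl on the ring nitrogen, this assay shows a number 2.5 percentage points lower from compound 2 to compound 3 (within the scatter) and a number 8.6 percentage points lower from compound 1 to compound 3 (within the scatter). The read-out at this one concentration therefore does not separate the three aryl groups, even with trifluoromethyl and chlorine together on the ring, so this position now shows no sensitivity to the substitution changes covered here. No supporting data bear on why these numbers stay so close. Open, going by these compounds, is whether an amine or a carboxylic acid on this aryl ring would leave the read-out equally flat. Also open, on these data alone, is whether these compounds would separate at other concentrations.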